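The source may report more compounds than this note shows. Statements on the series, on what has been measured and on what is new or still open speak of the compounds shown alone.

Measured so far:
Compound 1, `CCCCCc1cc2ccccc2nc1-c1cn(-c2ccc(F)cc2)nn1`, in a functional assay on HeLa cells (Homo sapiens) for cytotoxicity, read by MTT assay, with a stated time of 24 h (on this read-out higher numbers stand for weaker inhibition and lower numbers for stronger inhibition), gives only a limit of the assay, > 100 ug/mL.
Compound 2, `CCCCc1cc2ccccc2nc1-c1cn(-c2ccc(F)cc2)nn1`, in this assay likewise gives only a limit, > 100 ug/mL.
Compound 3, `CCCc1cc2ccccc2nc1-c1cn(CCC(F)(F)C(F)(F)C(F)(F)C(F)(F)C(F)(F)C(F)(F)C(F)(F)C(F)(F)F)nn1`, in this assay gives 37.8 ug/mL.

Compound 1 and compound 2 share one core and differ by methyl in place of hydrogen on a saturated chain carbon, four bonds along the chain from an aromatic carbon. Because both of their values sit at the limit of > 100 ug/mL in this assay, at which 2 of the 3 values shown sit, the step that the two limits leave unreadable from compound 2 to compound 1 has no readable size. Compound 3 carries a different core; the difference between the two cores is not broken down here.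

Compound 4, `CCCCc1cc2ccccc2nc1-c1cn(CCC(F)(F)C(F)(F)C(F)(F)C(F)(F)C(F)(F)C(F)(F)C(F)(F)C(F)(F)F)nn1`, is not yet measured and differs from compound 3 by methyl in place of hydrogen on a saturated chain carbon, three bonds along the chain from an aromatic carbon. Going by the values given here, this is the same kind of change as the one from compound 2 to compound 1, but not the same: there the new methyl sits four bonds along the chain from an aromatic carbon, here three bonds along the chain from an aromatic carbon.

Compound 4 is expected to give 35 ug/mL in this assay, most likely between 15 ug/mL and 80 ug/mL. That expectation rests on compound 3 at 37.8 ug/mL and on the step that the two limits leave unreadable from compound 2 to compound 1, which showed no readable size. The expected step of a 1.1-fold lower number from compound 3 to compound 4 (0.03 log units; within the scatter) is thus estimated to stay within the usual scatter.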

Compound 4, half-maximal inhibitory concentration: 32.8 ug/mL
Estimate against measurement, compound 4: 1.1-fold (0.03 log units) above; measured number inside the range.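

In this assay, going from propyl to butyl on the core of compound 3 gives a 1.2-fold lower number from compound 3 to compound 4 (0.06 log units; within the scatter), so on this core the added methyl leaves the result within the usual variation between repeat measurements. The closest comparison on the other core, where the new methyl sits four bonds along the chain from an aromatic carbon rather than three, cannot be read, because compound 1 and compound 2 both give only a limit of the assay, not a number: the limit of > 100 ug/mL in this assay, at which 2 of the 4 values shown sit. The change therefore has one readable size, on one core, and nothing here shows whether that size carries over to the core of compound 1.

On these data alone, it remains open whether a longer chain such as hexyl, or an amine or a carboxylic acid at the end of the chain, would shift the result on the core of compound 3. As far as these compounds go, it is also open which change on the core of compound 1 would yield a readable number at all.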